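Swapping fluoro for chloro on the anilino ring

The source may hold more compounds than are shown below. What is called first, only, known or untested is meant among the compounds shown, and "the series" means these compounds.

Compound 1, `O=C(C1=C(O)C(=O)N(CCCn2ccnc2)C1c1ccc(Br)cc1)c1ccccc1`, gives 73100 nM in a functional assay on A549 cells (Homo sapiens) for antiproliferative activity, read by MTT assay, with a stated time of 72 h; a higher number here means a weaker inhibitor, a lower number a stronger inhibitor.
Compound 2, `O=C(C1=C(Nc2ccc(F)cc2)C(=O)N(CCCn2ccnc2)C1c1ccc(Br)cc1)c1ccccc1`, gives 27400 nM in this assay.

For the measured compounds named here, of the two measured compounds, compound 2 has the lowest number; its nearest neighbour is compound 1, and the only measured step, a 2.7-fold lower number from compound 1 to compound 2 (0.43 log units; beyond the scatter), separates them, which is more than the usual scatter of repeated measurements.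

Compound 3, `O=C(C1=C(Nc2ccc(Cl)cc2)C(=O)N(CCCn2ccnc2)C1c1ccc(Br)cc1)c1ccccc1`, is not yet measured. It differs from compound 2 in one place: chloro in place of fluoro on an aromatic carbon. Going by the values given here, no measured step exchanges one halogen for another. Among the compounds with values here, the single measured step, a 2.7-fold lower number from compound 1 to compound 2 (0.43 log units; beyond the scatter), concerns a different change, the arrival of the whole (4-fluorophenyl)amino group, so it says little about the effect of trading fluoro for chloro on that ring. With nothing closer to lean on, the expectation for this assay is a step no larger than the usual scatter, in either direction. Accordingly, compound 3 is estimated at 22000 nM, with a likely range from 8000 nM to 60000 nM, which corresponds to an expected 1.2-fold lower number from compound 2 to compound 3 (0.10 log units; within the scatter).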

Compound 3, half-maximal inhibitory concentration: 30000 nM
Beside the measured number, compound 3's estimate is 1.4-fold (0.13 log units) below it; the range from low to high includes it.
By their numbers in this assay, from the lowest: compounds 2 and 3 (each within the scatter of the next); then compound 1.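

For the compounds shown here, exchanging (4-fluorophenyl)amino for (4-chlorophenyl)amino gives the first direct reading of a halogen swap on this ring: this assay shows a 1.1-fold higher number from compound 2 to compound 3 (0.04 log units; within the scatter) and so does not tell these two halogens apart at this position. The step from the hydroxy compound shows that fluoro is not needed for the lower number, since chloro also gives a 2.4-fold lower number from compound 1 to compound 3 (0.39 log units; beyond the scatter) and thus stays beyond the scatter, much like a 2.7-fold lower number from compound 1 to compound 2 (0.43 log units; beyond the scatter) with fluoro. Nothing available explains why the two halogens read alike or why either arylamino group gives a lower number than hydroxy.

Fluoro and chloro are only two close relatives, so it remains open whether the ring needs any halogen at all, which a plain phenyl ring with hydrogen at this position would test. Going by these compounds, it is also open whether a different kind of group here, such as methoxy, a carboxylic acid or a dimethylamino group, would shift the number beyond the scatter.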